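A few compounds are considered here, and "the series" means these few. Any claim that something is new, unique, unknown or untested is made for them only; others in the source may bear on it.

In an ADME assay on S9 fraction from liver (Rattus norvegicus, strain Wistar) for metabolic stability, tested at 0.1 uM (on this read-out higher numbers stand for fast clearance and lower numbers for slow clearance), three compounds with a shared core, differing only in the amino group on an aromatic carbon, have been measured. Compound 1 `CN(C)c1cc(OCc2cc(F)c(Oc3ccc(Cl)c(C(F)(F)F)c3)c(F)c2)nc(=O)n1C`, with dimethylamino, gives 82.8 mL/min/kg. Compound 2 `CCN(CC)c1cc(OCc2cc(F)c(Oc3ccc(Cl)c(C(F)(F)F)c3)c(F)c2)nc(=O)n1C`, with diethylamino, gives 41.9 mL/min/kg. Compound 3 `CN(c1cc(OCc2cc(F)c(Oc3ccc(Cl)c(C(F)(F)F)c3)c(F)c2)nc(=O)n1C)C1CC1`, with cyclopropyl(methyl)amino, gives 123 mL/min/kg.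

Compound 3 has the highest number of the three, but that lead is firm only against compound 2. The modest 2.9-fold higher number from compound 2 to compound 3 (0.47 log units; beyond the scatter) lies beyond the scatter, while a 1.5-fold higher number from compound 1 to compound 3 (0.17 log units; within the scatter) stays within it, as does a 2.0-fold lower number from compound 1 to compound 2 (0.30 log units; within the scatter).

The next compound is compound 4 `CCOC(=O)CN(C)c1cc(OCc2cc(F)c(Oc3ccc(Cl)c(C(F)(F)F)c3)c(F)c2)nc(=O)n1C`, which has (ethoxycarbonyl)methyl in place of cyclopropyl on a nitrogen on an aromatic ring. Within the data shown here, the entering group is an open chain with no ring, and no measured compound carries anything like it, so the three steps offer only indirect guidance. Among the measured compounds shown here, they do show how far changes at this amino group have moved this assay so far, with a 2.9-fold higher number from compound 2 to compound 3 (0.47 log units; beyond the scatter) as the largest. With no evidence for a direction, no shift beyond the scatter is expected, and the estimated step is a 1.1-fold lower number from compound 3 to compound 4 (0.05 log units; within the scatter). The wide range allows for the novelty of the group. The expected value for compound 4 is 110 mL/min/kg, within an estimated range from 50 mL/min/kg to 230 mL/min/kg.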

Compound 4, clearance: 13.8 mL/min/kg
Compound 4: middle estimate off by 8.0-fold (0.90 log units), on the high side; the whole stated range lies above it.
By their numbers in this assay, from the lowest: compound 4; then compounds 2, 1 and 3 (each within the scatter of the next, the first and the last beyond it).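

Among these compounds, compound 4 is the first compound here to stand beyond the scatter from every other one, and the lowest number in this assay so far, so this position on the amino group can carry a much larger drop than the earlier simple alkyl and cyclopropyl groups suggested: the steps are an 8.9-fold lower number from compound 3 to compound 4 (0.95 log units; beyond the scatter) and a 3.0-fold lower number from compound 2 to compound 4 (0.48 log units; beyond the scatter) and a 6.0-fold lower number from compound 1 to compound 4 (0.78 log units; beyond the scatter) with the group change in each case at the same nitrogen. The last of these is the simplest to read, since ethoxycarbonyl replaces only a hydrogen on the saturated chain carbon bound to that nitrogen, which ties the drop to the added ethoxycarbonyl unit and sets it apart from the swaps among small groups. Nothing in the data explains why the number falls this far.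

The compounds shown cannot separate the part played by the carbonyl from that of the ethyl end or of the longer chain alone. From the compounds shown here alone, a carboxylic acid, an amide or a plain butyl chain on the same nitrogen would be needed to tell these apart, and whether the drop holds with any of them remains open.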